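Thiosemicarbazone series: aryl hydroxy exchanged for fluoro

This account rests on a few compounds, and the source may have more. Where it says the series, first, only, none or still open, it means among the compounds named here.

Measured so far:
compound 1, `CC1=CC[C@H](C(C)(C)N=C=S)CC1`; in a functional assay on K562 cells (Homo sapiens) for inhibition, read by sulforhodamine B assay, with a stated time of 48 h (on this read-out higher numbers stand for weaker inhibition of growth and lower numbers for stronger inhibition of growth), compound 1 gives 4000 nM.
compound 2, `CC1=CC[C@H](C(C)(C)NC(=S)N/N=C/c2ccc(O)cc2)CC1`; in this assay compound 2 gives > 100000 nM, a limit of the assay rather than a number.

Compound 2 therefore stands at the limit of > 100000 nM in this assay, at which 1 of the 2 values shown sits, so its growth inhibition is only bounded. Compound 3, `CC1=CC[C@H](C(C)(C)NC(=S)N/N=C/c2ccc(F)cc2)CC1`, differs from compound 2 by fluoro in place of hydroxy on an aromatic carbon. Among the compounds with values here, no step between measured compounds is available to draw on. With a single heavy atom exchanged, no step beyond the scatter is expected in this assay, so compound 3 is expected to remain near the limit. The expected step from compound 2 to compound 3 is a number no higher from compound 2 to compound 3 (the limit leaves the size open). Compound 3 is estimated at 100000 nM, with a range from 20000 nM to 300000 nM.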

Compound 3, concentration for 50% growth inhibition: > 100000 nM
Compound 3: no number, only a limit; the forecaster's own chance of this, stated with the estimate: 65%; the middle value sits exactly at the limit.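

Within the data shown here, no step from compound 2 to compound 3 can be read in this assay, because each compound gives only a limit of the assay: the limit of > 100000 nM in this assay, at which 2 of the 3 values shown sit. The compounds shown leave open whether 4-hydroxyphenyl and 4-fluorophenyl differ at all in growth inhibition.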